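The source may hold more compounds than are shown below. What is called first, only, known or untested is meant among the compounds shown, and "the series" means these compounds.

Compound 3 `Cc1c(C(=O)N[C@@H](C)c2cccc(C(F)(F)F)c2F)cnn1-c1ccc(Cl)cc1` is the most potent of the three measured compounds: in a functional assay on cells for antagonist activity at C-C chemokine receptor type 1 (Homo sapiens), read by FLIPR and calcium flux (a lower number here means a stronger inhibitor, a higher number a weaker inhibitor), compound 3 gives 28 nM, a number clearly lower than those of the other two. Compound 1 `Cc1c(C(=O)NCc2cccc(C(F)(F)F)c2)cnn1-c1ccc(Cl)cc1` gives 600 nM in this assay, and compound 2 `O=C(NCc1cccc(C(F)(F)F)c1)c1cnn(-c2ccc(Cl)cc2)c1CO` gives 1200 nM. Among the compounds with values here, the only one-place step that has been measured, a 2.0-fold higher number from compound 1 to compound 2 (0.30 log units; within the scatter), touches a different part of the shared core and does not speak to the change considered here.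

Compound 4 `CC[C@H](NC(=O)c1cnn(-c2ccc(Cl)cc2)c1C)c1cccc(C(F)(F)F)c1F` differs from compound 3 by methyl in place of hydrogen on a saturated chain carbon, two bonds along the chain from an amide-type nitrogen and an aromatic carbon. Within the data shown here, no measured pair alters this chain carbon, so there is no direct guide to the size of the step. Among the measured compounds shown here, the one step that is known replaced a single hydrogen by a small group and stayed within the scatter, which offers only weak support for expecting a small effect. For compound 4 the expected step is therefore a 1.3-fold higher number from compound 3 to compound 4 (0.10 log units; within the scatter), not beyond the scatter. Compound 4 is estimated at 35 nM, within a range from 12 nM to 100 nM.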

Compound 4, half-maximal inhibitory concentration: 13 nM
Compound 4: the middle estimate sits 2.7-fold (0.43 log units) above what was measured, within the range that was stated.
By their numbers in this assay, from the lowest: compound 4; then compound 3; then compounds 1 and 2 (each within the scatter of the next).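

In this assay, within the data shown here, the change from methyl to ethyl on this saturated chain carbon gives a 2.2-fold lower number from compound 3 to compound 4 (0.33 log units; beyond the scatter), so this position, which no earlier pair touched, does respond to a change, and one added carbon here is tolerated without loss. The step is modest, yet it is the first single-place step among these compounds to lie beyond the scatter, since the hydroxy step from compound 1 to compound 2 stayed within it. Nothing available explains why the number falls. From the compounds shown here alone, it remains open whether a longer chain such as propyl, or a branched group such as isopropyl, on this carbon would lower the number further or reverse the step. Also open, going by these compounds, is how a hydroxy or an amine on the ethyl chain would read.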